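The source may hold more compounds than are shown below. What is called first, only, known or untested is meant among the compounds shown, and "the series" means these compounds.

Of the compounds shown here, three built on one shared core have been measured in an assay on isolated protein for inhibition of Indoleamine 2,3-dioxygenase 1 (Homo sapiens); on this read-out lower numbers stand for stronger inhibition and higher numbers for weaker inhibition. Compound 1 `OCCc1cn(CCNc2nonc2/C(=N/O)Nc2ccc(F)c(Br)c2)nn1` gives 247 nM. Compound 2 `CCC(O)c1cn(CCNc2nonc2/C(=N/O)Nc2ccc(F)c(Br)c2)nn1` gives 73 nM. Compound 3 `CC(C)(O)c1cn(CCNc2nonc2/C(=N/O)Nc2ccc(F)c(Br)c2)nn1` gives 115 nM, which places compound 3 second highest of the three numbers, nearest to compound 2 and furthest from compound 1. The steps between them are these: a 3.4-fold lower number from compound 1 to compound 2 (0.53 log units; beyond the scatter); a 2.1-fold lower number from compound 1 to compound 3 (0.33 log units; beyond the scatter); and a 1.6-fold higher number from compound 2 to compound 3 (0.20 log units; within the scatter). Compound 4 `CC(OCCO)c1cn(CCNc2nonc2/C(=N/O)Nc2ccc(F)c(Br)c2)nn1` has not yet been measured. It differs from compound 3 in one place: 1-(2-hydroxyethoxy)ethyl in place of 1-hydroxy-1-methylethyl on an aromatic carbon, on the five-membered aromatic ring with 3 nitrogen. The earlier steps shown here bear on this change only loosely. Each of the three measured groups carries a hydroxyl and they differ in the arrangement of their carbons; both changes away from the shortest group were modest, and the step between the two branched groups stayed within the scatter. The new group again carries a hydroxyl, now through a longer chain. In this assay the expected step is therefore a 1.0-fold lower number from compound 3 to compound 4 (0.02 log units; within the scatter), nothing beyond the scatter. Compound 4 is estimated to give about 110 nM, within a range from 45 nM to 270 nM.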

Compound 4, half-maximal inhibitory concentration: 134 nM
For compound 4 the middle estimate is 1.2-fold (0.09 log units) below the measured one, within the range that was stated.
By their numbers in this assay, from the lowest: compounds 2, 3, 4 and 1 (each within the scatter of the next, the first and the last beyond it).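

Replacing 1-hydroxy-1-methylethyl with the longer 1-(2-hydroxyethoxy)ethyl, which has 6 heavy atoms instead of 4 and one more hydrogen-bond acceptor, leaves the read-out in this assay within the scatter, with a 1.2-fold higher number from compound 3 to compound 4 (0.07 log units; within the scatter) as the step. So this position on the ring tolerates a larger group with an ether oxygen in its chain, and compound 4 cannot be told apart from compound 2 (a 1.8-fold higher number from compound 2 to compound 4 (0.26 log units; within the scatter)) or from compound 1 (a 1.8-fold lower number from compound 1 to compound 4 (0.27 log units; within the scatter)), even though those two differ from each other by more than the scatter. No supporting measurement is available to explain this result.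

On these data alone, all four groups carry a hydroxyl, so it remains open whether that hydroxyl matters at this position. A plain ethyl group, an amine or a carboxylic acid here would help to answer that.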